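The source may report more compounds than this note shows. Statements on the series, on what has been measured and on what is new or still open speak of the compounds shown alone.

Of the compounds shown here, three have been measured in a functional assay on U2OS cells (Homo sapiens) for cytotoxicity, read by MTT assay, with a stated time of 48 h; on this read-out higher numbers stand for weaker inhibition and lower numbers for stronger inhibition. Compound 1, `Fc1ccc2nc(-c3ccccc3)nc(Nc3ccccc3)c2c1`, gives > 50000 nM, which is a limit of the assay. Compound 2, `Fc1ccc(Nc2nc(-c3cccc(F)c3)nc3ccc(F)cc23)cc1`, gives > 50000 nM, likewise a limit. Compound 3, `Fc1cccc(-c2nc(Nc3cccc(Br)c3)c3cc(F)ccc3n2)c1`, gives > 50000 nM, again a limit.

Compound 3 therefore stands where every measured compound stands: at the limit of > 50000 nM in this assay, at which 3 of the 3 values shown sit, with no number of its own. For the measured compounds named here, the one step between measured neighbours, a step that the two limits leave unreadable from compound 2 to compound 3, is unreadable for the same reason, so nothing in the data shows whether changing the aryl group on the nitrogen on the aromatic ring moves the read-out at all.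

Compound 4, `Cc1ccccc1Nc1nc(-c2cccc(F)c2)nc2ccc(F)cc12`, is not yet measured. It differs from compound 3 by 2-methylphenyl in place of 3-bromophenyl on a nitrogen on an aromatic ring. Going by the values given here, no measured step speaks to this change, and the only evidence is that all three values sit at the limit. The expectation for compound 4 is thus no step beyond the scatter in this assay, with the estimated change a step that the limit leaves unreadable from compound 3 to compound 4 most likely again hidden behind a limit. Compound 4 is estimated at 60000 nM, within 25000 nM to 150000 nM.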

Compound 4, half-maximal inhibitory concentration: > 50000 nM
Compound 4 gave a limit, no number; the forecaster's own chance of this, stated with the estimate: 85%; the middle value is on the limit's open side.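

In this assay compound 4 gives > 50000 nM, which is a limit and not a number. No step from compound 2 or compound 3 to compound 4 can be read: the limit of > 50000 nM in this assay, at which 4 of the 4 values shown sit.

The compounds shown leave open whether any group on the nitrogen on an aromatic ring would bring the read-out to a measurable number.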